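This account rests on a few compounds, and the source may have more. Where it says the series, first, only, none or still open, it means among the compounds named here.

Compound 1 `CCCCOc1ccc(-c2c(C)[nH]c(=O)n2C)cc1`: 5100 nM
Compound 2 `CCCCCOc1ccc(-c2c(C)[nH]c(=O)n2C)cc1`: 4500 nM
Compound 3 `Cc1[nH]c(=O)n(C)c1-c1ccc(OCCC(C)C)cc1`: 6600 nM

In a functional assay on brain (Rattus norvegicus, strain Wistar) for inhibition (on this read-out lower numbers stand for stronger inhibition and higher numbers for weaker inhibition), compound 3 gives 6600 nM and cannot be ranked against the other two: the steps of a 1.3-fold higher number from compound 1 to compound 3 (0.11 log units; within the scatter) and a 1.5-fold higher number from compound 2 to compound 3 (0.17 log units; within the scatter) both lie within the scatter. Compound 4 `CCCCCCCOc1ccc(-c2c(C)[nH]c(=O)n2C)cc1` carries pentyl in place of isopropyl on a saturated chain carbon, two bonds along the chain from an oxygen on an aromatic ring. The closest evidence is the step of a 1.1-fold lower number from compound 1 to compound 2 (0.05 log units; within the scatter), together with the branching step already given. Going by the values given here, neither exceeds the scatter, but no measured compound has a chain as long as this one, so the range must stay wide. The expected change is a 1.5-fold lower number from compound 3 to compound 4 (0.17 log units; within the scatter), which means no real shift is anticipated. For compound 4 the estimate is 4500 nM, with an expected range of 1800 nM to 10000 nM.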

Compound 4, half-maximal inhibitory concentration: 5700 nM
Beside the measured number, compound 4's estimate is 1.3-fold (0.10 log units) below it, and the stated range covers the measured number.
By their numbers in this assay, from the lowest: compounds 2, 1, 4 and 3 (each within the scatter of the next).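

In this assay, the step out to the heptyl chain gives no readable shift (a 1.3-fold higher number from compound 2 to compound 4 (0.10 log units; within the scatter); a 1.1-fold higher number from compound 1 to compound 4 (0.05 log units; within the scatter)), and neither does the exchange of isopropyl for pentyl (a 1.2-fold lower number from compound 3 to compound 4 (0.06 log units; within the scatter)). Going by these compounds alone, all three steps lie within the scatter, so the flat picture from the earlier compounds now extends to a longer chain at this position. Nothing measured here speaks to why the numbers stay so close.

Going by these compounds, whether a chain longer than heptyl, or one ending in an amine or a carboxylic acid, would shift the number remains open.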